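The source may report more compounds than this note shows. Statements on the series, on what has been measured and on what is new or still open speak of the compounds shown alone.

Working notes on the series. The shared core carries two enone arms and a phenyl group; compound 1 `Cc1cc(O)c(C(=O)/C=C/c2ccc(F)cc2)c(-c2ccccc2)c1C(=O)/C=C/c1ccc(F)cc1` has fluorine on both arms. In a functional assay on MCF7 cells (Homo sapiens) for cytotoxicity, read by MTT assay, with a stated time of 24 h (a higher number here means a weaker inhibitor, a lower number a stronger inhibitor), compound 1 gives 20000 nM. Compound 2 `Cc1cc(O)c(C(=O)/C=C/c2ccc(Cl)cc2)c(-c2ccccc2)c1C(=O)/C=C/c1ccc(Cl)cc1` carries chlorine on both arms instead, and in this assay compound 2 gives 10000 nM; the two values sit within the scatter of each other, so no order can be read between compounds 1 and 2. In this assay compound 3 `COc1ccc(/C=C/C(=O)c2c(C)cc(O)c(C(=O)/C=C/c3ccc(OC)c(OC)c3)c2-c2ccccc2)cc1OC`, with dimethoxy arms, is reported as "not active" (no number reported), and no number is given for it. Compound 1 thus holds the highest of the two numbers on record, with compound 2 nearest.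

Compound 4 `Cc1cc(O)c(C(=O)/C=C/c2ccc(F)cc2)c(-c2ccc(Br)cc2)c1C(=O)/C=C/c1ccc(F)cc1` is not yet measured. It differs from compound 1 by bromo in place of hydrogen on an aromatic carbon; the same difference read one bond further out is phenyl to 4-bromophenyl. Within the data shown here, no pair of measured compounds shows this change, so the series itself gives nothing to set its size. The numbers available are all weak or absent, and the expectation is a step of no more than the scatter in either direction. Compound 4 is therefore expected near 15000 nM, with a range from 5000 nM to 50000 nM. The step expected from compound 1 to compound 4 is a 1.3-fold lower number from compound 1 to compound 4 (0.12 log units; within the scatter).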

Compound 4, half-maximal inhibitory concentration: 20000 nM
Compound 4: middle estimate off by 1.3-fold (0.12 log units), on the low side, within the range that was stated.
By their numbers in this assay, from the lowest: compounds 2, 1 and 4 (each within the scatter of the next).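

Among these compounds, the phenyl group of the shared core now has its first reading, since the earlier compounds differed only on the two arms: in this assay, the step for bromo in place of hydrogen on an aromatic carbon, para to a large group, is no change at the digits printed from compound 1 to compound 4 (within the scatter). Phenyl to 4-bromophenyl therefore leaves the number unmoved in this pair, and the added bromine brings no step beyond the scatter, although this one pair is all that speaks for the position. No measurement is at hand that could explain this flat step.

On these data alone, whether an amine or a carboxylic acid at the same place on this ring would move the number beyond the scatter remains open. Also open, as far as these compounds go, is whether 4-bromophenyl would give the same reading with chlorine on both arms in place of fluorine, or whether a methoxy group at this place would behave as bromo does.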